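The compounds below may be only part of what the source reports. "The series", "measured", "known", "first", "only" and "open" are said of these compounds alone.

In a functional assay on Bel-7402 cells (Homo sapiens) for antiproliferative activity, read by MTT assay, with a stated time of 72 h (on this read-out lower numbers stand for stronger inhibition and higher numbers for weaker inhibition), compound 2 `C=C1C(=O)O[C@H]2[C@H]1CC/C(COC(=O)Cn1cc(F)c(=O)n(Cc3ccc(C(F)(F)F)cc3)c1=O)=C\CC[C@@]1(C)O[C@@H]21` gives 2250 nM and compound 3 `C=C1C(=O)O[C@H]2[C@H]1CC/C(COC(=O)Cn1cc(F)c(=O)n(Cc3cccc(F)c3)c1=O)=C\CC[C@@]1(C)O[C@@H]21` gives 2530 nM, two values within the scatter of each other. Compound 1 `C=C1C(=O)O[C@H]2[C@H]1CC/C(COC(=O)CCC(=O)NCCCCCCNC(=O)Cn1cc(F)c(=O)[nH]c1=O)=C\CC[C@@]1(C)O[C@@H]21` reaches only a limit, > 20000 nM. Compound 4 `C=C1C(=O)O[C@H]2[C@H]1CC/C(COC(=O)Cn1cc(F)c(=O)n(C)c1=O)=C\CC[C@@]1(C)O[C@@H]21` has hydrogen in place of 3-fluorophenyl on a saturated chain carbon bound to an aromatic nitrogen, which turns 3-fluorobenzyl into methyl: hydrogen in place of 3-fluorophenyl on a saturated chain carbon bound to an aromatic nitrogen. Among the compounds with values here, the one measured step at this place, a 1.1-fold higher number from compound 2 to compound 3 (0.05 log units; within the scatter), exchanged one aromatic group for another and stayed within the scatter, so it does not show what removing the ring does. A modest move toward weaker inhibition is tentatively expected, a 1.8-fold higher number from compound 3 to compound 4 (0.25 log units; within the scatter). Compound 4 is expected at 4500 nM, with an estimated range of 1500 nM to 15000 nM.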

Compound 4, half-maximal inhibitory concentration: 9400 nM
The estimate for compound 4 lay 2.1-fold (0.32 log units) below the measured number, and the stated range covers the measured number.
By their numbers in this assay, from the lowest: compounds 2 and 3 (each within the scatter of the next); then compound 4. At a limit, above all of these: compound 1.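

Methyl in place of the ring-bearing groups raises the number, and a 3.7-fold higher number from compound 3 to compound 4 (0.57 log units; beyond the scatter) and a 4.2-fold higher number from compound 2 to compound 4 (0.62 log units; beyond the scatter) stand in this assay as the first steps at this place beyond the scatter. So having an aromatic ring on this chain counts here, although exchanging one substituted ring for the other did not register. Nothing shown gives a cause for this change.

On these data alone, whether a plain benzyl group, or a longer chain such as butyl without a ring, would match compound 2 and compound 3 stays open. So does whether an amine or a carboxylic acid on the ring would be tolerated.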